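Replacing the 2,3-dihydroxypropyl group of compound 1

The compounds below may be only part of what the source reports. "The series", "measured", "known", "first", "only" and "open" are said of these compounds alone.

Measured in a functional assay on SH-SY5Y cells (Homo sapiens) for cytotoxicity, read by MTT assay, with a stated time of 72 h (on this read-out lower numbers stand for stronger inhibition and higher numbers for weaker inhibition), as follows
- Compound 1 `O=C1c2c[n+]([O-])c3ccccc3c2C(=O)c2c1c1ccccc1n2Cc1cn(CC(O)CO)nn1` gives > 1000 nM as a limit
- Compound 2 `CCCN1CCN(CCCCn2c3c(c4ccccc42)C(=O)c2c[n+]([O-])c4ccccc4c2C3=O)CC1` gives 3970 nM as its value
- Compound 3 `CN1CCN(CCCn2c3c(c4ccccc42)C(=O)c2c[n+]([O-])c4ccccc4c2C3=O)CC1` gives 560 nM as its value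

Compound 1 has only a limit of > 1000 nM and no exact number. Compound 4 `O=C1c2c[n+]([O-])c3ccccc3c2C(=O)c2c1c1ccccc1n2Cc1cn([C@H]2C[C@H](O)[C@@H](CO)O2)nn1` keeps the core of compound 1 and differs in one group on an aromatic nitrogen (4-hydroxy-5-(hydroxymethyl)oxolan-2-yl in place of 2,3-dihydroxypropyl on an aromatic nitrogen). Going by the values given here, no measured step makes this exchange. The nearest ones remove the whole group that carries it: the first (an at least 1.7-fold lower number from compound 1 to compound 3 (0.25 log units; that floor lies within the scatter)) has a floor within the scatter, and the limit leaves the second (a step that the limit leaves unreadable from compound 1 to compound 2) unreadable. A third step (a 7.1-fold lower number from compound 2 to compound 3 (0.85 log units; beyond the scatter)) lies beyond the scatter but concerns a different group. No step beyond the scatter is therefore expected in this assay for this exchange, in either direction. The expected change is small (a step that the limit leaves unreadable from compound 1 to compound 4). Compound 4 is estimated at 2000 nM (expected range 700 nM to 6000 nM).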

Compound 4, half-maximal inhibitory concentration: 620 nM
Beside the measured number, compound 4's estimate is 3.2-fold (0.51 log units) above it; measured number below the stated range.
By their numbers in this assay, from the lowest: compounds 3 and 4 (each within the scatter of the next); then compound 2.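

In this assay, the change to 4-hydroxy-5-(hydroxymethyl)oxolan-2-yl on this aromatic nitrogen gives an at least 1.6-fold lower number from compound 1 to compound 4 (0.20 log units; that floor lies within the scatter). The position therefore accepts a five-membered non-aromatic ring with 3 defined stereocentres, and compound 4 gives an exact value of 620 nM. The true size of the step stays unknown, since compound 1 has only a limit: the limit of > 1000 nM in this assay, at which 1 of the 4 values shown sits.

The compounds shown do not separate the contribution of the ring from that of its stereocentres. Going by these compounds, what a simple amine or a carboxylic acid on this nitrogen would give also remains open.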